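Oxan-3-yl for ethyl on the piperidine amide of compound 3

The source may hold more compounds than are shown below. What is called first, only, known or untested is meant among the compounds shown, and "the series" means these compounds.

Compound 3 `CCC(=O)N1CCC(NC(=O)Nc2ccc(OC(F)(F)F)c(F)c2)CC1` gives 99.2% in an ADME assay on a cell-free system (plasma, Homo sapiens) for protein binding, tested at 1 uM, the lowest unbound fraction among the three compounds measured. Compound 2 `CC(C)C(=O)N1CCC(NC(=O)Nc2ccc(OC(F)(F)F)c(F)c2)CC1` gives 98.7%; the one-place change a 1.6-fold lower unbound fraction from compound 2 to compound 3 (0.21 log units; within the scatter) stays within the scatter. Going by the values given here, compound 1 `O=C(Nc1ccc(OC(F)(F)F)cc1)NC1CCN(C(=O)C2CCCOC2)CC1` gives 94.1%, the furthest from compound 3 and beyond the scatter, but compound 1 differs from compound 3 in two places, so no single step is known for that gap.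

Compound 4 `O=C(Nc1ccc(OC(F)(F)F)c(F)c1)NC1CCN(C(=O)C2CCCOC2)CC1` arises from compound 3 by oxan-3-yl in place of ethyl on a carbonyl carbon. Among the compounds with values here, no measured step covers this change alone. Compound 1 carries the same oxan-3-yl carbonyl without the ring fluorine of compound 3 and compound 4, so compound 1 with 94.1% and compound 3 with 99.2% together bracket where compound 4 may fall, without separating the two changes. The step a 3.1-fold higher unbound fraction from compound 3 to compound 4 (0.49 log units; beyond the scatter) is therefore expected to lean toward a higher unbound fraction, though it may well stay within the scatter. For compound 4 the expected value is 97.5%, estimated between 94.5% and 99%.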

Compound 4, plasma protein binding: 99.4%
The estimate for compound 4 lay 4.2-fold (0.62 log units) (unbound fraction) above the measured number; measured number above the stated range.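

In this assay, oxan-3-yl in place of ethyl on the carbonyl carbon gives a 1.3-fold lower unbound fraction from compound 3 to compound 4 (0.12 log units; within the scatter), so a ring and a hydrogen-bond acceptor enter at this place without a step beyond the scatter. Oxan-3-yl in place of isopropyl gives a 2.2-fold lower unbound fraction from compound 2 to compound 4 (0.34 log units; beyond the scatter), a modest step, although compound 2 and compound 3 lie within the scatter of each other. With oxan-3-yl held constant, fluoro in place of hydrogen on an aromatic carbon gives a 9.8-fold lower unbound fraction from compound 1 to compound 4 (0.99 log units; beyond the scatter), the largest step available in the series, and this isolates the effect of that one change on the gap seen from compound 1.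

As far as these compounds go, whether an amine or a carboxylic acid on this carbonyl carbon would shift the binding remains open, as does the size of the fluoro step with ethyl or isopropyl on the carbonyl carbon. No available data explain the size of these steps.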